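This account rests on a few compounds, and the source may have more. Where it says the series, first, only, none or still open, it means among the compounds named here.

In a functional assay on OVCAR-8 cells (Homo sapiens) (a higher number here means a weaker inhibitor of growth, a lower number a stronger inhibitor of growth), compound 1 (`O=S(=O)(/C=C/c1ccc(F)cc1)Cc1ccc(Nc2ncnc3ccccc23)cc1`) gives 2000 nM and compound 2 (`O=S(=O)(/C=C/c1ccc(Br)cc1)Cc1ccc(Nc2ncnc3ccccc23)cc1`) gives 38000 nM. Compound 3 (`O=S(=O)(/C=C/c1ccc(Cl)cc1)Cc1ccc(Nc2ncnc3ccccc23)cc1`) gives > 100000 nM, which is a limit and not a number. It is the weakest of the three. Compound 4 (`O=S(=O)(/C=C/c1ccc(Cl)cc1Cl)Cc1ccc(Nc2ncnc3ccccc23)cc1`) differs from it by chloro in place of hydrogen on an aromatic carbon: chloro in place of hydrogen, ortho to a large group and meta to a chloro group, so 4-chlorophenyl becomes 2,4-dichlorophenyl. Within the data shown here, no measured step adds a group in this way. The nearest are halogen swaps: a 19-fold higher number from compound 1 to compound 2 (1.28 log units; beyond the scatter), an at least 50-fold higher number from compound 1 to compound 3 (1.69 log units; beyond the scatter) and an at least 2.6-fold higher number from compound 2 to compound 3 (0.42 log units; beyond the scatter). These show large moves on small changes but give no direction for this one. A modest to large step towards a lower number is tentatively expected, estimated as an at least 3.3-fold lower number from compound 3 to compound 4 (0.52 log units; beyond the scatter). For compound 4 the estimated value is 30000 nM, with an expected range of 5000 nM to 100000 nM.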

Compound 4, concentration for 50% growth inhibition: 4000 nM
Beside the measured number, compound 4's estimate is 7.5-fold (0.88 log units) above it; measured number below the stated range.
By their numbers in this assay, from the lowest: compounds 1 and 4 (each within the scatter of the next); then compound 2. At a limit, above all of these: compound 3.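

In this assay, among these compounds, chloro in place of hydrogen, ortho to a large group and meta to a chloro group, is the only added group, and it gives an at least 25-fold lower number from compound 3 to compound 4 (1.39 log units; beyond the scatter). Compound 3 stands at a limit, not a number: the limit of > 100000 nM in this assay, at which 1 of the 4 values shown sits. The 2,4-dichlorophenyl group improves on 4-bromophenyl, with a 9.5-fold lower number from compound 2 to compound 4 (0.98 log units; beyond the scatter), and stays level with 4-fluorophenyl, with a 2.0-fold higher number from compound 1 to compound 4 (0.30 log units; within the scatter).

Still open, from the compounds shown here alone, is what a methoxy group or a 2-chlorophenyl group would give here, and whether adding chloro to 4-fluorophenyl or 4-bromophenyl has a similar effect.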